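Ethylsulfonylamino in place of propoxy: expected shift

A few compounds are considered here, and "the series" means these few. Any claim that something is new, unique, unknown or untested is made for them only; others in the source may bear on it.

Within the data shown here, compound 2 `CCCOc1cccnc1-c1ccc(C(=O)Nc2ccc(C(C)(C)C)cc2)cc1` is the one compound of the pair with a number in a functional assay for antagonist activity at transient receptor potential cation channel subfamily V member 1 (Homo sapiens), read by FLIPR (a lower number here means a stronger inhibitor, a higher number a weaker inhibitor), where compound 2 gives 62 nM. Compound 1 `Cc1cccnc1-c1ccc(C(=O)Nc2ccc(F)cc2)cc1` sits at the limit of > 4000 nM in this assay, at which 1 of the 2 values shown sits; in this assay compound 1 gives > 4000 nM, which is a limit and not a number. Compound 3 `CCS(=O)(=O)Nc1cccnc1-c1ccc(C(=O)Nc2ccc(C(C)(C)C)cc2)cc1` differs from compound 2 by (ethylsulfonyl)amino in place of propoxy on an aromatic carbon. Among the measured compounds shown here, no measured step covers such an exchange, so the expectation rests on compound 2 at 62 nM alone. The step is expected to be a loss beyond the scatter, a 3.2-fold higher number from compound 2 to compound 3 (0.51 log units; beyond the scatter). Compound 3 is estimated at 200 nM, within 40 nM to 1500 nM.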

Compound 3, half-maximal inhibitory concentration: 49 nM
Compound 3: the middle estimate sits 4.1-fold (0.61 log units) above what was measured; the range from low to high includes it.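

In this assay, the aromatic carbon two atoms from the ring nitrogen accepts (ethylsulfonyl)amino in place of propoxy: a 1.3-fold lower number from compound 2 to compound 3 (0.10 log units; within the scatter). This position therefore carries a larger group with a hydrogen-bond donor, which propoxy lacks, without a loss beyond the scatter. Nothing measured here accounts for this tolerance.

Still open, on these data alone, is how a simple amine or a carboxylic acid on this carbon would read. As far as these compounds go, it is also open whether a longer chain on the sulfonyl group would hold the value of compound 3 at 49 nM.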